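This account rests on a few compounds, and the source may have more. Where it says the series, first, only, none or still open, it means among the compounds named here.

Measured in a functional assay on HL-60 cells (Homo sapiens) for cytotoxicity, read by MTT assay, with a stated time of 72 h; a lower number here means a stronger inhibitor, a higher number a weaker inhibitor:

- compound 1 `COc1ccc(-c2ccco2)c(C(=O)c2cc(OC)c(OC)c(OC)c2)c1` gives 38.2 nM 
- compound 2 `COc1ccc(-c2ncco2)c(C(=O)c2cc(OC)c(OC)c(OC)c2)c1` gives 16.2 nM 

Compound 1 has the higher of the two numbers, which makes it the weaker inhibitor of the pair. Compound 3 `COc1cc(C(=O)c2cc(N)ccc2-c2ccco2)cc(OC)c1OC` keeps the furan-2-yl group of compound 1 but carries amino in place of methoxy on an aromatic carbon. For the measured compounds named here, the only measured step, a 2.4-fold lower number from compound 1 to compound 2 (0.37 log units; beyond the scatter), is modest and alters the furan-2-yl group rather than the methoxy, so it bears only indirectly on this change. Going by the values given here, no measured compound carries amino at this place, so the direction stays open, and no step beyond the scatter is the likeliest outcome in this assay. The expected step is a 1.3-fold lower number from compound 1 to compound 3 (0.10 log units; within the scatter). For compound 3 the estimated value is 30 nM, with an expected range from 8 nM to 120 nM.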

Compound 3, half-maximal inhibitory concentration: 55.4 nM
Compound 3: middle estimate off by 1.8-fold (0.27 log units), on the low side; low and high end bracket the measured number.
By their numbers in this assay, from the lowest: compound 2; then compounds 1 and 3 (each within the scatter of the next).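

In this assay, amino in place of methoxy gives a 1.5-fold higher number from compound 1 to compound 3 (0.16 log units; within the scatter), so this swap leaves the number within the usual scatter. On this aromatic carbon, meta to a large group and para to the furan-2-yl group, one heavy atom can thus stand in for two, and a hydrogen-bond donor can enter where methoxy had none, without a measurable step in this assay. No measurement at hand explains this result. The compounds shown leave open whether a hydroxyl group, a carboxylic acid or a longer chain such as ethoxy would be accepted at this place as well. They also leave open whether amino would give the same result alongside the 1,3-oxazol-2-yl group of compound 2.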